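Ester in place of tetrazole on the biaryl carbon

A few compounds are considered here, and "the series" means these few. Any claim that something is new, unique, unknown or untested is made for them only; others in the source may bear on it.

Measured so far:
Compound 1 `CC(C)(N)CC(=O)N[C@@H]1CCc2ccccc2N(Cc2ccc(-c3ccccc3C(N)=O)cc2)C1=O` gives in a functional assay (Pituitary gland cell) with Rattus norvegicus as the target (on this read-out higher numbers stand for an effect only at larger amounts of compound and lower numbers for an effect already at smaller amounts), a value of 0.08 uM.
Compound 2 `CC(O)Cn1nnnc1-c1ccccc1-c1ccc(CN2C(=O)[C@H](NC(=O)CC(C)(C)N)CCc3ccccc32)cc1` gives in this assay a value of 0.05 uM.

For the measured compounds named here, compound 2 stands at the lowest of the two numbers, but the only other number lies within the scatter of it: a 1.6-fold lower number from compound 1 to compound 2 (0.20 log units; within the scatter).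

Compound 3 `COC(=O)c1ccccc1-c1ccc(CN2C(=O)[C@H](NC(=O)CC(C)(C)N)CCc3ccccc32)cc1` differs from compound 2 in one place: methoxycarbonyl in place of 1-(2-hydroxypropyl)-1H-tetrazol-5-yl on an aromatic carbon.

Going by the values given here, the one measured step that bears on this change is the one above, on the same aromatic carbon, and it stayed within the scatter. Among the compounds with values here, no measured step covers the methoxycarbonyl group itself. The expectation is therefore no step beyond the scatter, with some allowance for a somewhat higher number. For compound 3 the expected step is a 1.6-fold higher number from compound 2 to compound 3 (0.20 log units; within the scatter). For compound 3 the estimate in this assay is 0.08 uM, with a range from 0.03 uM to 0.25 uM.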

Compound 3, concentration for half-maximal effect: 2 uM
The estimate for compound 3 lay 25-fold (1.40 log units) below the measured number; the whole stated range lies below it.
By their numbers in this assay, from the lowest: compounds 2 and 1 (each within the scatter of the next); then compound 3.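

Methoxycarbonyl on this aromatic carbon is not tolerated as the two earlier groups were: in this assay it brings a 40-fold higher number from compound 2 to compound 3 (1.60 log units; beyond the scatter) and, against the carbamoyl group, a 25-fold higher number from compound 1 to compound 3 (1.40 log units; beyond the scatter) in the same read-out. Carbamoyl and 1-(2-hydroxypropyl)-1H-tetrazol-5-yl had stayed within the scatter of each other, so the earlier agreement between two very different groups does not extend to every group at this place, and the amide and the methyl ester are not interchangeable here. No available data bear on the reason for this step.

As far as these compounds go, whether the loss follows the methoxy group itself or the carbonyl group in general remains open. A carboxylic acid, a methylamide or a hydroxymethyl group on this carbon would help separate these readings in this assay.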